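The source may hold more compounds than are shown below. What is called first, only, known or untested is meant among the compounds shown, and "the series" means these compounds.

Series notes. Three compounds share one core and differ only in the ester chain: compound 1 `CCOc1cc(NC(=O)C2(NC(=O)c3ccc4c(C5CCCC5)c(-c5ncc(Cl)cn5)n(C)c4c3)CCC2)ccc1/C=C/C(=O)OCOP(=O)(O)O`, compound 2 `CCOc1cc(NC(=O)C2(NC(=O)c3ccc4c(C5CCCC5)c(-c5ncc(Cl)cn5)n(C)c4c3)CCC2)ccc1/C=C/C(=O)OCC(C)C` and compound 3 `CCOc1cc(NC(=O)C2(NC(=O)c3ccc4c(C5CCCC5)c(-c5ncc(Cl)cn5)n(C)c4c3)CCC2)ccc1/C=C/C(=O)OCCOCCOC`. In an ADME assay (liver) for pharmacokinetics, with Liver microsome (Rattus norvegicus) as the target, using microsomes (on this read-out lower numbers stand for a shorter-lived compound and higher numbers for a longer-lived compound), compound 1 gives 0.15 h, compound 2 gives 1.42 h and compound 3 gives 1.07 h. Compound 2 stands highest of the three numbers, but the step of a 1.3-fold lower number from compound 2 to compound 3 (0.12 log units; within the scatter) lies within the scatter, whereas a 9.5-fold higher number from compound 1 to compound 2 (0.98 log units; beyond the scatter) and a 7.1-fold higher number from compound 1 to compound 3 (0.85 log units; beyond the scatter) are both beyond it; only the member carrying the phosphorus-containing group sits apart.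

Next is compound 4 `CCOc1cc(NC(=O)C2(NC(=O)c3ccc4c(C5CCCC5)c(-c5ncc(Cl)cn5)n(C)c4c3)CCC2)ccc1/C=C/C(=O)OCC(N)=O`. Against compound 2 the change is carbamoyl in place of isopropyl on a saturated chain carbon bound to an oxygen next to a carbonyl group. Among the measured compounds shown here, the steps that bear on this are the ones within the ester chain: (2-methoxyethoxy)methyl in place of isopropyl moved nothing beyond the scatter, and the large step belonged to the phosphorus-containing group alone, which carbamoyl is not. On that basis the expected step from compound 2 to compound 4 in this assay is a 1.6-fold lower number from compound 2 to compound 4 (0.20 log units; within the scatter), not clearly beyond the scatter. Compound 4 is accordingly estimated at 0.9 h, with a range from 0.35 h to 2 h.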

Compound 4, half-life: 0.383 h
Beside the measured number, compound 4's estimate is 2.3-fold (0.37 log units) above it; the measured number falls inside the stated range.
By their numbers in this assay, from the lowest: compound 1; then compound 4; then compounds 3 and 2 (each within the scatter of the next).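

In this assay the ester chain is no longer silent outside the phosphorus-containing member: a 3.7-fold lower number from compound 2 to compound 4 (0.57 log units; beyond the scatter) and a 2.8-fold lower number from compound 3 to compound 4 (0.45 log units; beyond the scatter) both lie beyond the scatter, so on a saturated chain carbon bound to an oxygen next to a carbonyl group, carbamoyl shifts the number where (2-methoxyethoxy)methyl in place of isopropyl did not. Compound 4 also stays apart from the phosphorus-containing member, with a 2.6-fold higher number from compound 1 to compound 4 (0.41 log units; beyond the scatter) beyond the scatter, so the series now reads as three levels, with compounds 2 and 3 together at the top. Nothing shown here gives a cause for this shift.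

As far as these compounds go, whether a carboxylic acid, an amine or dimethylcarbamoyl at this carbon would sit with compound 4 or with compound 2 remains open. So does whether carbamoyl on a longer chain would keep the step.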